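A few compounds are considered here, and "the series" means these few. Any claim that something is new, unique, unknown or untested is made for them only; others in the source may bear on it.

Working notes on the series. Within the data shown here, compound 3 `CN1CCN(c2ccc(Nc3ncc4nc(Nc5ccc(F)cc5)n([C@@H]5CCCN(C(=O)CO)C5)c4n3)cc2)CC1` stands second highest of the three numbers measured so far in a functional assay on HCC827 cells (Homo sapiens) for antiproliferative activity, read by MTT assay, with a stated time of 72 h; on this read-out higher numbers stand for weaker inhibition and lower numbers for stronger inhibition; compound 3 gives 66 nM. Its nearest neighbour is compound 1 `CN1CCN(c2ccc(Nc3ncc4nc(Nc5ccc(F)cc5)n([C@H]5CCCN(S(=O)(=O)C6CC6)C5)c4n3)cc2)CC1`, which in this assay gives 8.6 nM, and its furthest is compound 2 `CNC(=O)CN1CC[C@H](n2c(Nc3ccc(F)cc3)nc3cnc(Nc4ccc(N5CCN(C)CC5)cc4)nc32)C1`, which gives 1520 nM. Compound 4 `CN1CCN(c2ccc(Nc3ncc4nc(Nc5ccc(F)cc5)n(-c5cccc(NC(=O)CO)c5)c4n3)cc2)CC1` is not yet measured. The change in hand: 3-(((hydroxymethyl)carbonyl)amino)phenyl in place of 1-((hydroxymethyl)carbonyl)piperidin-3-yl on an aromatic nitrogen. All three known steps alter the same position on the aromatic nitrogen: a 7.7-fold higher number from compound 1 to compound 3 (0.89 log units; beyond the scatter), a 180-fold higher number from compound 1 to compound 2 (2.25 log units; beyond the scatter) and a 23-fold lower number from compound 2 to compound 3 (1.36 log units; beyond the scatter). Together they show that this position moves the number strongly and in both directions, while none of them exchanges the saturated ring for an aromatic one, so direct guidance for the present change is lacking. Given that the hydroxyacetyl amide of compound 3 is kept, a weakening beyond the scatter is expected for compound 4, of the order of a 3.0-fold higher number from compound 3 to compound 4 (0.48 log units; beyond the scatter), less severe than the worst case seen. Compound 4 is therefore estimated at 200 nM, with a range from 40 nM to 1000 nM.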

Compound 4, half-maximal inhibitory concentration: 7.5 nM
Compound 4: middle estimate off by 27-fold (1.43 log units), on the high side; the whole stated range lies above it.
By their numbers in this assay, from the lowest: compounds 4 and 1 (each within the scatter of the next); then compound 3; then compound 2.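

In this assay, among these compounds, this is the first exchange of the saturated ring for an aromatic one on the aromatic nitrogen, and with the (hydroxymethyl)carbonyl group retained it gives an 8.8-fold lower number from compound 3 to compound 4 (0.94 log units; beyond the scatter), so the saturated ring is not required at this position. The 3-(((hydroxymethyl)carbonyl)amino)phenyl group also matches the 1-(cyclopropylsulfonyl)piperidin-3-yl group, with a 1.1-fold lower number from compound 1 to compound 4 (0.06 log units; within the scatter), while a 200-fold lower number from compound 2 to compound 4 (2.31 log units; beyond the scatter) leaves compound 2 as the weakest of the four. No measurement at hand explains the gain.

The compounds shown do not separate the effect of the aromatic ring from that of the added hydrogen-bond donor, as both change in the one step. As far as these compounds go, how a free amine, a carboxylic acid or a longer chain would fare in place of the amide on the phenyl ring also remains open.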